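Swapping the Aminophenyl for a Methylthiophene on the Ketone

The source may hold more compounds than are shown below. What is called first, only, known or untested is meant among the compounds shown, and "the series" means these compounds.

Compound 1, `O=C(c1ccccc1)c1ccn(-c2ccc3c(c2)B(O)OC3)c1`: in an ADME assay on L929 cells (Mus musculus) for cytotoxicity, read by resazurin assay, with a stated time of 72 h (on this read-out higher numbers stand for weaker inhibition and lower numbers for stronger inhibition), compound 1 gives > 10 ug/mL, which is a limit of the assay and not a number.
Compound 2, `O=C(c1ccc(CO)cc1)c1ccn(-c2ccc3c(c2)B(O)OC3)c1`: compound 2 gives 9.31 ug/mL.
Compound 3, `Nc1ccc(C(=O)c2ccn(-c3ccc4c(c3)B(O)OC4)c2)cc1`: compound 3 gives 3.9 ug/mL.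

Among the two numbers given, compound 3 stands at the lowest; its nearest neighbour is compound 2, and the step of a 2.4-fold lower number from compound 2 to compound 3 (0.38 log units; beyond the scatter) lies beyond the scatter. Compound 4, `Cc1ccc(C(=O)c2ccn(-c3ccc4c(c3)B(O)OC4)c2)s1`, differs from compound 3 in one place: 5-methylthiophen-2-yl in place of 4-aminophenyl on a carbonyl carbon.

Among the compounds with values here, two measured steps bear on this change, both of them the ones that put the amino group onto the ring: an at least 2.5-fold lower number from compound 1 to compound 3 (0.40 log units; beyond the scatter) and a 2.4-fold lower number from compound 2 to compound 3 (0.38 log units; beyond the scatter). In each case the number fell when the amino group came in. Compound 4 gives that amino group up and replaces the whole ring at the same time, so the expectation is a step back in the other direction in this assay, of roughly the size seen when the amino group entered, landing near where compound 1 and compound 2 sit; the step is estimated as a 2.4-fold higher number from compound 3 to compound 4 (0.39 log units; beyond the scatter). Compound 4 is therefore expected to give 9.5 ug/mL, with a range from 4 ug/mL to 22 ug/mL, and it may well come back only as a limit.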

Compound 4, half-maximal inhibitory concentration: > 10 ug/mL
Compound 4: a limit, no number (the forecaster's own chance of this, stated with the estimate: 40%); middle value at least 1.0-fold (0.02 log units) from the limit.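

In this assay, this change shows that the lower number of compound 3 does not survive when the 4-aminophenyl on the carbonyl carbon gives way to a 5-methylthiophen-2-yl, a five-membered aromatic ring with no hydrogen-bond donor: the result is an at least 2.5-fold higher number from compound 3 to compound 4 (0.40 log units; beyond the scatter). Set against the other measured ketone with a number, the reading is an at least 1.0-fold higher number from compound 2 to compound 4 (0.03 log units; that floor lies within the scatter), so the data do not separate the 5-methylthiophen-2-yl from the 4-(hydroxymethyl)phenyl, and among these compounds only the 4-aminophenyl stands clearly apart from the 5-methylthiophen-2-yl. The step between compound 1 and compound 4 cannot be read, because each of the two stands at a limit of the assay and not at a number: the limit of > 10 ug/mL in this assay, at which 2 of the 4 values shown sit.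

The ring and the amino group change together in compound 4, which leaves open whether the amino group alone accounts for the low number of compound 3 or whether the six-membered ring also plays a part. An amino group carried on the methylthiophene ring, or a dimethylamino group or carboxylic acid in its place on the phenyl ring, would begin to pull those two questions apart.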